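Fluoro to methoxy swap on the aryl ring

The source may hold more compounds than are shown below. What is called first, only, known or untested is meant among the compounds shown, and "the series" means these compounds.

Two compounds of the series carry numbers in a functional assay on HeLa cells (Homo sapiens) for cytotoxicity, read by MTT assay, with a stated time of 2 days, tested at 1 uM; on this read-out higher numbers stand for a weaker effect at the one concentration tested and lower numbers for a stronger effect. Compound 1 `COc1ccc(-c2cc(C(C)=O)c3[nH]c(-c4ccccc4)cc3c2)cc1` gives 73.1%. Compound 2 `CC(=O)c1cc(-c2ccc(F)cc2)cc2cc(-c3ccc(F)cc3)[nH]c12` gives 71.6%. For the measured compounds named here, the two numbers lie within the scatter of each other, so compound 1 and compound 2 cannot be told apart on this read-out, and no step between measured compounds that differ in one place is available; what the change does has to be judged from these two values alone.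

Compound 3 `COc1ccc(-c2cc(C(C)=O)c3[nH]c(-c4ccc(F)cc4)cc3c2)cc1` has not been measured. It differs from compound 2 in one place: methoxy in place of fluoro on an aromatic carbon. Compound 3 thus keeps the 4-fluorophenyl of compound 2 and takes the 4-methoxyphenyl of compound 1, combining groups from both measured compounds. Because compound 1 with 73.1% and compound 2 with 71.6% sit within the scatter of each other, the step of a number 0.4 percentage points higher from compound 2 to compound 3 (within the scatter) is expected to be none beyond the scatter, in no fixed direction. Compound 3 is expected to give 72% in this assay, with an estimated range from 62% to 82%.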

Compound 3, a percentage reported as activity, at one concentration (the size of the read-out at that concentration, not a potency): 56.1%
For compound 3 the middle estimate is 15.9 percentage points above the measured one; measured number outside the range, below it.
By their numbers in this assay, from the lowest: compound 3; then compounds 2 and 1 (each within the scatter of the next).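

In this assay, methoxy in place of fluoro on the aromatic carbon para to a large group gives a number 15.5 percentage points lower from compound 2 to compound 3 (beyond the scatter) and fluoro in place of hydrogen on an aromatic carbon gives a number 17 percentage points lower from compound 1 to compound 3 (beyond the scatter), so compound 3, which holds both the 4-methoxyphenyl and the 4-fluorophenyl, stands apart from each of its two neighbours. The closeness of compound 1 and compound 2 therefore did not mean that the aryl groups are interchangeable, since the 4-fluorophenyl to 4-methoxyphenyl change at this position has a clear effect on this read-out when the other aryl group carries fluoro. Nothing on hand accounts for this effect of the two groups together.

The compounds shown leave open whether the gain is specific to methoxy at this position or would also appear with a hydroxyl, an amine or a longer alkoxy chain such as ethoxy in its place. They also leave open whether the stronger effect of compound 3 at this one concentration would hold at other concentrations, which a full concentration series on compound 2 and compound 3 would settle.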